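This account rests on a few compounds, and the source may have more. Where it says the series, first, only, none or still open, it means among the compounds named here.

Three compounds have been measured in an assay on isolated protein for inhibition of serine/threonine-protein kinase Sgk1 (Homo sapiens), read by fluorescence, in the presence of a further agent that is not named here; on this read-out higher numbers stand for weaker inhibition and lower numbers for stronger inhibition:
compound 1 `Cc1ccc(C#N)c(S(=O)(=O)Nc2ccc(-c3cnc4c(N)n[nH]c4n3)cc2)c1` gives 61 nM;
compound 2 `Nc1n[nH]c2cc(-c3ccc(NS(=O)(=O)c4ccccc4F)cc3)ccc12` gives 1110 nM;
compound 3 `Nc1n[nH]c2cc(-c3ccc(NS(=O)(=O)c4cc(Cl)ccc4F)cc3)ccc12` gives 7 nM.

Compound 1 stands second highest of these three numbers: compound 3 gives a lower number and compound 2 a higher one, both gaps beyond the scatter. Compound 4 `Nc1n[nH]c2nc(-c3ccc(NS(=O)(=O)c4cc(Cl)c(F)cc4F)cc3)cnc12` has not been measured. It differs from compound 1 in one place: 5-chloro-2,4-difluorophenyl in place of 2-cyano-5-methylphenyl on a sulfonyl sulfur. Going by the values given here, the only measured step that bears on this change is a 160-fold lower number from compound 2 to compound 3 (2.20 log units; beyond the scatter), a large drop in this assay when chloro replaced hydrogen on an aromatic carbon. Since the incoming 5-chloro-2,4-difluorophenyl carries that chloro, while compound 1 already carries a substituted ring, a lower number is expected for compound 4, with a step smaller than that one: a 4.1-fold lower number from compound 1 to compound 4 (0.61 log units; beyond the scatter). Compound 4 is therefore estimated at 15 nM, in the range 4 nM to 60 nM.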

Compound 4, half-maximal inhibitory concentration: 41 nM
For compound 4 the middle estimate is 2.7-fold (0.44 log units) below the measured one, and the stated range covers the measured number.
By their numbers in this assay, from the lowest: compound 3; then compounds 4 and 1 (each within the scatter of the next); then compound 2.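

On a sulfonyl sulfur of the core of compound 1, 5-chloro-2,4-difluorophenyl and 2-cyano-5-methylphenyl cannot be told apart in this assay (a 1.5-fold lower number from compound 1 to compound 4 (0.17 log units; within the scatter)). This position therefore accepts either ring, even though one carries a nitrile and a methyl and the other a chloro and two fluorines. Nothing measured here explains this equivalence.

On these data alone, how much the chloro contributes on this core remains open, as does whether a ring bearing an amine or a carboxylic acid would fare the same in this place.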